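A few compounds are considered here, and "the series" means these few. Any claim that something is new, unique, unknown or untested is made for them only; others in the source may bear on it.

Measured compounds:
compound 1 `COc1cccc(C(O)CCn2nc3c(Br)c(Br)c(Br)c(Br)c3n2)c1` — 97%
compound 2 `C[C@@H](O)CCn1nc2c(Br)c(Br)c(Br)c(Br)c2n1` — 86%
compound 3 `OC(CCn1nc2c(Br)c(Br)c(Br)c(Br)c2n1)c1ccccc1` — 113%

In a functional assay on MCF7 cells (Homo sapiens) for antiproliferative activity, read by MTT assay, with a stated time of 48 h, tested at 12.5 uM (a higher number here means a weaker effect of the compound at the concentration tested, a lower number a stronger effect), compound 3 gives the highest number of the three, with compound 1 lying a number 16 percentage points higher from compound 1 to compound 3 (beyond the scatter) below it and compound 2 further below still, both gaps beyond the scatter; compound 3 is therefore the weakest of the measured set at this concentration. Compound 4 `OC(CCn1nc2c(Br)c(Br)c(Br)c(Br)c2n1)c1ccc(Cl)cc1` has not been measured. Against compound 3 the difference is chloro in place of hydrogen on an aromatic carbon.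

Among the compounds with values here, the one measured step, a number 16 percentage points higher from compound 1 to compound 3 (beyond the scatter), concerns removal of a methoxy group from the same aromatic ring, not introduction of a chloro group, so it bears only loosely on the present change. It shows that a substituent on this ring can shift the number by a modest amount in this assay, but nothing on file fixes the direction for chloro. Compound 2, with no aromatic ring at all, is lowest, which says nothing direct about a para substituent either. The expected step from compound 3 to compound 4 is therefore a number 8 percentage points lower from compound 3 to compound 4 (within the scatter), small and within or at the edge of the scatter. For compound 4 the estimate in this assay is 105%, with a range from 88% to 120%.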

Compound 4, a percentage reported as activity, at one concentration (the size of the read-out at that concentration, not a potency): 100%
For compound 4 the middle estimate is 5 percentage points above the measured one, within the range that was stated.
By their numbers in this assay, from the lowest: compound 2; then compounds 1 and 4 (each within the scatter of the next); then compound 3.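

In this assay, chloro in place of hydrogen on an aromatic carbon, para to a large group, gives a number 13 percentage points lower from compound 3 to compound 4 (beyond the scatter), so this position responds to a single chlorine atom; read with a number 16 percentage points higher from compound 1 to compound 3 (beyond the scatter), this places both substituted phenyl compounds of this pair of steps on the lower side of compound 3, the unsubstituted one. The comparison of the two substituted rings gives a number 3 percentage points higher from compound 1 to compound 4 (within the scatter), so in these notes 4-chlorophenyl and 3-methoxyphenyl cannot be told apart at this concentration, even though the group and its place on the ring both differ. Nothing on file accounts for the size or the direction of the chloro step.

Whether the lower number belongs to substitution on this ring in general remains open, since only chloro and methoxy are shown, and an amine or a carboxylic acid at the same position could behave differently. Also open, from the compounds shown here alone, is whether the chloro step holds with a longer chain between the hydroxyl-bearing carbon and the shared core, and whether chloro and methoxy would separate if each sat at the other's place on the ring.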